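Phenyl for isopentyl on the shared core

A few compounds are considered here, and "the series" means these few. Any claim that something is new, unique, unknown or untested is made for them only; others in the source may bear on it.

The study compares compound 1, `COc1cccc(Oc2ccc3c(NCCCNCc4cc(F)ccc4OC)ccnc3c2)c1`, with compound 2, `COc1ccc(F)cc1CNCCCNc1ccnc2cc(CCC(C)C)ccc12`, in an ADME assay on HepG2 cells (Homo sapiens) for cytotoxicity, read by luminescence, CellTiter-Glo and ATP content, with a stated time of 72 h; on this read-out lower numbers stand for an effect already at smaller amounts and higher numbers for an effect only at larger amounts of compound. Compound 1 gives 7100 nM, while compound 2 gives 890 nM, the lowest of the two numbers; the step is an 8.0-fold lower number from compound 1 to compound 2 (0.90 log units; beyond the scatter). Compound 3, `COc1ccc(F)cc1CNCCCNc1ccnc2cc(-c3ccccc3)ccc12`, has not yet been measured in this assay. It differs from compound 2 by phenyl in place of isopentyl on an aromatic carbon, on the aromatic carbon where the change from compound 1 to compound 2 also took place. Within the data shown here, only that one step, an 8.0-fold lower number from compound 1 to compound 2 (0.90 log units; beyond the scatter), bears on the new change, and it concerns a different group entering the same carbon, so it gives direction only loosely. A phenyl carries an aromatic ring as the departing group of compound 1 did, and compound 2 is therefore expected to move by a 2.0-fold higher number from compound 2 to compound 3 (0.31 log units; beyond the scatter) toward a somewhat higher number. Compound 3 is thus estimated at 1800 nM, within a range from 500 nM to 6500 nM.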

Compound 3, half-maximal effective concentration: 2960 nM
For compound 3 the middle estimate is 1.6-fold (0.22 log units) below the measured one; low and high end bracket the measured number.
By their numbers in this assay, from the lowest: compound 2; then compound 3; then compound 1.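

In this assay, phenyl on this aromatic carbon does not match isopentyl: the number rises (a 3.3-fold higher number from compound 2 to compound 3 (0.52 log units; beyond the scatter)). Nor does phenyl match 3-methoxyphenoxy, since the number falls when it takes that group's place (a 2.4-fold lower number from compound 1 to compound 3 (0.38 log units; beyond the scatter)). The three groups therefore give three separate levels at this one carbon, and the two aromatic groups both stand above isopentyl while still differing from each other beyond the scatter. Nothing given here explains these differences. The compounds shown cannot say whether the gap between phenyl and 3-methoxyphenoxy comes from the ether oxygen or from the methoxy group. As far as these compounds go, how an amine, a carboxylic acid or a chain longer than isopentyl would read at this carbon also stays open.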